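From Hydroxy to Bromo on a Phenyl Group

The source may report more compounds than this note shows. Statements on the series, on what has been measured and on what is new or still open speak of the compounds shown alone.

Compound 1 `COc1ccccc1-n1cc(CN2C(=O)C[C@@H]3CC[C@@]2(C)C3(C)C)nn1` gives 110 nM
Compound 2 `CC1(C)[C@H]2CC[C@]1(C)N(Cc1cn(-c3ccc(O)cc3)nn1)C(=O)C2` gives 80 nM

In a functional assay on HepG2 cells (Homo sapiens) for inhibition, read by MTT assay, with a stated time of 24 h (a higher number here means a weaker inhibitor, a lower number a stronger inhibitor), compound 2 at 80 nM stands within the scatter of compound 1 at 110 nM and holds no clear rank. Compound 3 `CC1(C)[C@H]2CC[C@]1(C)N(Cc1cn(-c3ccc(Br)cc3)nn1)C(=O)C2` has bromo in place of hydroxy on an aromatic carbon. Within the data shown here, only one measured step bears on this change, a 1.4-fold lower number from compound 1 to compound 2 (0.14 log units; within the scatter), and it stayed within the scatter. As far as these compounds go, that step involved other groups, so bromo itself remains untested. No step beyond the scatter is therefore expected in this assay. The expected change is a 1.1-fold lower number from compound 2 to compound 3 (0.06 log units; within the scatter) as estimated here. For compound 3 the estimate is 70 nM with 25 nM to 200 nM as the expected range.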

Compound 3, half-maximal inhibitory concentration: 110 nM
Estimate against measurement, compound 3: 1.6-fold (0.20 log units) below, and the stated range covers the measured number.
By their numbers in this assay, from the lowest: compounds 2, 1 and 3 (each within the scatter of the next).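

In this assay, bromo in place of hydroxy gives a 1.4-fold higher number from compound 2 to compound 3 (0.14 log units; within the scatter), so this para position on the phenyl ring is now probed directly, and removing the hydrogen-bond donor and acceptor of hydroxy leaves the number within the scatter. The step to the 4-bromophenyl group gives no change at the digits printed from compound 1 to compound 3 (within the scatter), which also stays within the scatter. Nothing available explains why the numbers stay so close. 

As far as these compounds go, whether an amine or a carboxylic acid at this position would move the number beyond the scatter remains open.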